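The source may report more compounds than this note shows. Statements on the series, on what has been measured and on what is new or still open speak of the compounds shown alone.

Values in a physicochemical assay for solubility; a higher number here means a more soluble compound, a lower number a less soluble compound:
- compound 1 `CS(=O)(=O)c1ccc(-n2nc(C(F)(F)F)cc2-c2ccccc2)nc1`: 50 ug/mL
- compound 2 `CS(=O)(=O)c1ccc(-n2nc(C(F)(F)F)cc2NC2CCCC2)nc1`: 25 ug/mL
- compound 3 `CS(=O)(=O)c1ccc(-n2nc(C(F)(F)F)cc2OC2CCCC2)nc1`: 50 ug/mL
- compound 4 `CC(C)(C)COc1cc(C(F)(F)F)nn1-c1ccc(S(C)(=O)=O)cn1`: not yet measured

Compound 3 gives 50 ug/mL, level with compound 1 at the digits available. Together they hold the highest number of the three, though compound 2 at 25 ug/mL lies within the scatter of both.

The next step is from compound 3 to compound 4. The change is neopentyl in place of cyclopentyl on an oxygen on an aromatic ring. In short, the ring of the cyclopentyl group is opened out into the neopentyl chain, and the oxygen stays in place.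

For the measured compounds named here, no measured pair holds the oxygen fixed and alters only the group on it, so the evidence is indirect. The nearest guide is the set of replacements on the aromatic carbon: no change at the digits printed from compound 1 to compound 3 (within the scatter), a 2.0-fold higher number from compound 2 to compound 3 (0.30 log units; within the scatter) and a 2.0-fold lower number from compound 1 to compound 2 (0.30 log units; within the scatter). All three stay within the scatter, so the three measured compounds show little spread in this assay, even with larger changes than this one. On these data alone, on that basis, no shift beyond the scatter is expected, and the direction remains open. The expected step is a 1.3-fold lower number from compound 3 to compound 4 (0.10 log units; within the scatter). For compound 4 the estimated value is 40 ug/mL, with an expected range from 15 ug/mL to 90 ug/mL.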

Compound 4, solubility: 100 ug/mL
For compound 4 the middle estimate is 2.5-fold (0.40 log units) below the measured one; the measured number lies above the stated range.
By their numbers in this assay, from the lowest: compounds 2, 1, 3 and 4 (each within the scatter of the next, the first and the last beyond it).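

In this assay the oxygen is now held fixed while only the group on it changes, and opening the cyclopentyl ring into the neopentyl chain gives a step that stays within the scatter (a 2.0-fold higher number from compound 3 to compound 4 (0.30 log units; within the scatter)), so this position tolerates the loss of that ring without a readable change in the number. The series also gains its first step beyond the scatter, a modest one (a 4.0-fold higher number from compound 2 to compound 4 (0.60 log units; beyond the scatter)), whereas the step from the phenyl compound remains within it (a 2.0-fold higher number from compound 1 to compound 4 (0.30 log units; within the scatter)); the first of these changes both the atom on the aromatic carbon and the group it carries, so it cannot be assigned to either alone. Nothing measured here gives a reason for these numbers.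

On these data alone, a neopentylamino group in this place would separate the contribution of the oxygen from that of the chain in the step beyond the scatter, and that comparison remains open. Also open, as far as these compounds go, is whether a longer chain on the oxygen, or a chain ending in a carboxylic acid, would move the number beyond the scatter from compound 4.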